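This account rests on a few compounds, and the source may have more. Where it says the series, first, only, none or still open, it means among the compounds named here.

Measured compounds:

Compound 1 `COC(=O)c1cc(-n2cc(-c3cccc(O)c3)nn2)ccc1O`: 6%
Compound 2 `O=C(O)c1cc(-n2cc(-c3cccc(O)c3)nn2)ccc1O`: 5%
Compound 3 `COc1ccccc1-c1cn(-c2ccc(O)c(C(=O)O)c2)nn1`: 4%

All three measured compounds were tested in a functional assay on HCT-116 cells (Homo sapiens) for inhibition, read by MTT assay, with a stated time of 2 days, tested at 10 uM; on this read-out lower numbers stand for less inhibition and higher numbers for more inhibition at the one concentration tested (going by the name of the read-out). Compound 1 gives 6%, compound 2 gives 5% and compound 3 gives 4%; the three numbers lie within the usual scatter of one another, so no order among them can be read from this assay.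

Compound 2 and compound 1 differ in one place, (methyl in place of hydrogen on an oxygen next to a carbonyl group). The step this change made is a number 1 percentage points higher from compound 2 to compound 1 (within the scatter).

Compound 3 and compound 2 share the hydroxy-bearing ring carrying the carbonyl group, but the difference between the two cores is not broken down here.

Compound 4 `COC(=O)c1cc(-n2cc(-c3ccccc3OC)nn2)ccc1O` has not yet been measured. Relative to compound 3 the change is methyl in place of hydrogen on an oxygen next to a carbonyl group, which is the same change as that seen between compound 2 and compound 1, at the same place.

In this assay, going by the values given here, the only measured instance of this change, from compound 2 to compound 1, stayed within the scatter, and compound 3 itself sits in the same low range as compound 2. On that basis the step from compound 3 to compound 4 is expected to be small, about a number 1 percentage points higher from compound 3 to compound 4 (within the scatter).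

Compound 4 is therefore estimated at 5% in this assay, with a range from -2% to 13% expected to cover most repeat measurements.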

Compound 4, a percentage reported as inhibition, at one concentration (the size of the read-out at that concentration, not a potency): 8%
Estimate against measurement, compound 4: 3 percentage points below; the range from low to high includes it.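

In this assay, carboxy to methoxycarbonyl on the second core gives a number 4 percentage points higher from compound 3 to compound 4 (within the scatter). Set beside the earlier instance of the same change, the two steps do not differ: the same change on two cores in this assay, a number 1 percentage points higher (within the scatter) from compound 2 to compound 1 and a number 4 percentage points higher (within the scatter) from compound 3 to compound 4, 3 percentage points apart, within the scatter of two such steps. Going by these compounds alone, this shows only that the change stays within the scatter on both cores; it does not show an effect that carries from one core to the other, as neither step stands clear of the scatter, and two cores are a narrow basis for any rule about this series.

The one other step available, 2-methoxyphenyl in place of 3-hydroxyphenyl on an aromatic carbon, gives a number 2 percentage points higher from compound 1 to compound 4 (within the scatter), so the compounds shown leave open whether any change in this series moves the number in this assay beyond the scatter at the one concentration tested. Also open, as far as these compounds go, is how the read-out responds to an amide in place of the ester, a longer chain in place of the methyl on that oxygen, or an amine on the aryl group.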